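Turning One Double Bond in Compound 2

The source may hold more compounds than are shown below. What is called first, only, known or untested is meant among the compounds shown, and "the series" means these compounds.

- Compound 1 `CCN(CC)CCCn1c(=O)/c(=C/c2ccc(F)cc2F)s/c1=C1/C(=O)Nc2cc(F)ccc21`: 3690 nM
- Compound 2 `CCN(CC)CCCn1c(=O)/c(=C/c2ccc(F)c(F)c2)s/c1=C1/C(=O)Nc2ccc(F)cc21`: 13400 nM
- Compound 3 `CCN(CC)CCCn1c(=O)/c(=C/c2cc(OC)c(OC)c(OC)c2)s/c1=C1\C(=O)Nc2ccc(C)cc21`: 4170 nM

These three compounds were tested in a functional assay on K562 cells (Homo sapiens) for cytotoxicity, read by sulforhodamine B assay, with a stated time of 48 h; on this read-out lower numbers stand for stronger inhibition and higher numbers for weaker inhibition. Compound 2 stands highest of the three, making it the weakest, and both of the others lie lower by more than the usual scatter.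

Compound 4 `CCN(CC)CCCn1c(=O)/c(=C/c2ccc(F)c(F)c2)s/c1=C1\C(=O)Nc2ccc(F)cc21` departs from compound 2 in configuration only: the two compounds have the same atoms and bonds and differ only in configuration as drawn: 1 of 2 stereo elements differ; a double bond is drawn E in compound 2 and Z in compound 4. Nothing leaves and nothing enters, and a double bond is drawn E in compound 2 and Z in compound 4.

Among the compounds with values here, no measured pair shows this change alone, so its size remains uncertain. The expectation leans towards a moderately lower number, and it rests only on where the other compounds sit: compound 1 gives 3690 nM and compound 3 gives 4170 nM. The expected change is a 1.9-fold lower number from compound 2 to compound 4 (0.28 log units; within the scatter), though a result within the scatter would not surprise. For compound 4 the estimated value is 7000 nM, with an expected range from 2500 nM to 20000 nM.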

Compound 4, half-maximal inhibitory concentration: 13400 nM
Estimate against measurement, compound 4: 1.9-fold (0.28 log units) below; low and high end bracket the measured number.
By their numbers in this assay, from the lowest: compounds 1 and 3 (each within the scatter of the next); then compounds 2 and 4 (each within the scatter of the next).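

Turning the one double bond from E to Z as drawn gives, in this assay, no change at the digits printed from compound 2 to compound 4 (within the scatter). Within the data shown here, this pair is the first to isolate a single difference, and in it the drawn configuration of this double bond does not separate the two compounds on this read-out. The comparison carries no other structural difference: the fact that compounds 2 and 4 differ only in the configuration as drawn

As far as these compounds go, the result rests on this single pair, and compound 1 and compound 3 have no partner here with the same double bond turned, so it remains open whether the same would hold for them. Also open, from the compounds shown here alone, is how the number would respond if a morpholine or a piperazine stood in place of the diethylamino group.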